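The source may report more compounds than this note shows. Statements on the series, on what has been measured and on what is new or still open speak of the compounds shown alone.

Compound 1 `Cc1cc(C)c(S(=O)(=O)N2CCN(C3CN4CCC3CC4)CC2)c(C)c1` and compound 2 `Cc1ccc(-c2ccccc2S(=O)(=O)N2CCC(N3CCC(C)CC3)CC2)cc1` have both been tested in a functional assay on DLD-1 cells (Homo sapiens) for antiproliferative activity, read by CellTiter-Glo, with a stated time of 72 h; on this read-out higher numbers stand for weaker inhibition and lower numbers for stronger inhibition. Compound 1 gives 84 nM in this assay, the lower of the two numbers. Compound 2 gives 366 nM in this assay, a higher number that lies beyond the usual scatter, so compound 1 is the stronger inhibitor of the pair. These two compounds differ in several places at once, so the gap cannot be tied to any single change. Compound 3 `Cc1cc(C)c(S(=O)(=O)N2CCN(C3CCN(C)CC3)CC2)c(C)c1` has not yet been tested. It differs from compound 1 in one place only: a group of 7 heavy atoms (6 carbon, 1 nitrogen; one six-membered non-aromatic ring with 1 hetero atom) in place of a group of 8 heavy atoms (7 carbon, 1 nitrogen; 2 six-membered non-aromatic rings with 1 hetero atom each), on an amine nitrogen in a ring. For the measured compounds named here, no measured step of this kind exists here, so the change is expected to bring at most a modest shift toward a higher number, and the step of a 1.4-fold higher number from compound 1 to compound 3 (0.15 log units; within the scatter) is estimated to stay close to the scatter. Compound 3 is therefore expected to give 120 nM in this assay, within a range from 40 nM to 400 nM.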

Compound 3, half-maximal inhibitory concentration: 426 nM
For compound 3 the middle estimate is 3.6-fold (0.55 log units) below the measured one; the whole stated range lies below it.
By their numbers in this assay, from the lowest: compound 1; then compounds 2 and 3 (each within the scatter of the next).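

Replacing the group with two six-membered rings by 1-methylpiperidin-4-yl on the amine nitrogen in the ring gives a 5.1-fold higher number from compound 1 to compound 3 (0.71 log units; beyond the scatter) in this assay. For the compounds shown here, this is the first comparison here that differs in one place only, and it shows that the group at this position affects the read-out, even though the two groups have the same counts of hydrogen-bond donors and acceptors and neither has a net charge. Nothing given here explains the shift.

A single pair cannot show whether the second ring or some other difference between the two groups accounts for the step. An unsubstituted piperidin-4-yl group or an open-chain amine such as 2-(dimethylamino)ethyl at this position would help separate these possibilities, and the same swap on another core would test how far the step carries over.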